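Cytotoxicity Notes on an Amide Replacement

The source may hold more compounds than are shown below. What is called first, only, known or untested is meant among the compounds shown, and "the series" means these compounds.

In a toxicity assay on THP-1 cells (Homo sapiens) for inhibition (on this read-out higher numbers stand for lower toxicity in this test and lower numbers for higher toxicity in this test), every measured compound sits at a limit of the test rather than at a number. Compound 1 `CCCC(=O)Nc1ncc(-c2ccc(OC)cc2)n1C` gives > 100000 nM, a limit. Compound 2 `Cn1c(-c2ccc(C#N)cc2)cnc1NC(=O)c1ccc(F)cc1` gives > 50000 nM, likewise a limit. Compound 3 `COc1ccc(-c2cnc(NC(=O)c3ccc(F)cc3)[nH]2)cc1` gives > 100000 nM, again a limit. Going by the values given here, compound 1 therefore stands at the limit of > 100000 nM in this assay, at which 2 of the 3 values shown sit, which it shares with one other compound, and no step between measured compounds can be sized. Compound 4 `COc1ccc(-c2cnc(NC(=O)c3ccccc3F)n2C)cc1` differs from compound 1 by 2-fluorophenyl in place of propyl on a carbonyl carbon. Because compounds 2 and 3, which also carry an aryl group on the carbonyl carbon, sit at the limit of > 100000 nM in this assay, at which 2 of the 3 values shown sit, and (the limit of > 50000 nM in this assay, at which 1 of the 3 values shown sits), the step in this assay is expected to be none beyond the scatter, a number no higher from compound 1 to compound 4 (the limit leaves the size open). Compound 4 is thus estimated at 100000 nM, between 50000 nM and 200000 nM, most likely reported again only as a limit.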

Compound 4, half-maximal cytotoxic concentration: > 100000 nM
Compound 4: a limit, no number (the forecaster's own chance of this, stated with the estimate: 85%); the middle value lies on the limit itself.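

Compound 1 and compound 4 both sit at limits in this assay and the step between them, 2-fluorophenyl in place of propyl on a carbonyl carbon, cannot be read. The compounds shown leave open whether any member of the series reaches a measurable cytotoxic concentration in this assay at all.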